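A few compounds are considered here, and "the series" means these few. Any claim that something is new, unique, unknown or untested is made for them only; others in the source may bear on it.

Measured compounds:
- compound 1 `Cc1cccc(C2=NCCNc3c2c(C)nn3C)c1`: 2.5 mg/kg
- compound 2 `Cc1nn(C)c2c1C(c1cccc(O)c1)=NCCN2`: 2.5 mg/kg
- compound 3 `Cc1nn(C)c2c1C(c1cccc([N+](=O)[O-])c1)=NCCN2`: 5 mg/kg

Three compounds share one core and differ only in the group carried on an aromatic carbon. In a functional assay on the whole organism for positive allosteric modulation, with Rattus norvegicus as the target (on this read-out lower numbers stand for an effect already at smaller amounts and higher numbers for an effect only at larger amounts of compound), compound 1 gives 2.5 mg/kg, compound 2 gives 2.5 mg/kg, and compound 3 gives 5 mg/kg. On the numbers shown compound 3 carries the largest value, yet the steps leading to it, a 2.0-fold higher number from compound 1 to compound 3 (0.30 log units; within the scatter) and a 2.0-fold higher number from compound 2 to compound 3 (0.30 log units; within the scatter), remain within the scatter, as does no change at the digits printed from compound 1 to compound 2 (within the scatter); the three compounds are not separated by this read-out.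

Compound 4 `Cc1nn(C)c2c1C(c1cccc(N=[N+]=[N-])c1)=NCCN2` is the next member of the series. It differs from compound 3 by azido in place of nitro on an aromatic carbon. All three measured steps at this aromatic carbon, exchanging methyl, hydroxy and nitro, stayed within the scatter, so a change from nitro to azido at the same position is expected to leave the read-out essentially unchanged, with no step beyond the scatter in either direction, as expressed by a 1.4-fold lower number from compound 3 to compound 4 (0.15 log units; within the scatter). Compound 4 is therefore estimated at 3.5 mg/kg, with an expected range from 1.5 mg/kg to 10 mg/kg.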

Compound 4, minimum effective dose: 2.5 mg/kg
Compound 4: the middle estimate sits 1.4-fold (0.15 log units) above what was measured; measured number inside the range.
By their numbers in this assay, from the lowest: compounds 1, 2, 4 and 3 (each within the scatter of the next).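

In this assay placing azido on this aromatic carbon gives a 2.0-fold lower number from compound 3 to compound 4 (0.30 log units; within the scatter) while the exchanges from the other two groups give no change at the digits printed from compound 2 to compound 4 (within the scatter) and no change at the digits printed from compound 1 to compound 4 (within the scatter) at the same place. Azido, which brings three nitrogen atoms where nitro has one nitrogen and two oxygen atoms, thus joins methyl, hydroxy and nitro as a fourth group that this read-out does not separate from the others on the shared core. No measurement shown here bears on what lies behind these numbers.

From the compounds shown here alone, whether an amine, a carboxylic acid or a longer chain at this place would give a step beyond the scatter stays open. So does whether azido or any of the other three groups would read the same on another carbon of this ring.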